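A few compounds are considered here, and "the series" means these few. Any claim that something is new, unique, unknown or untested is made for them only; others in the source may bear on it.

Measured in a functional assay (trachea) for inhibition, with Cavia porcellus as the target; on this read-out lower numbers stand for stronger inhibition and higher numbers for weaker inhibition:
- compound 1 `O=c1c2ccccc2c(-c2ccccc2)nn1CCCn1ccnc1`: 11000 nM
- compound 2 `O=c1c2ccccc2c(-c2ccccc2)nn1CCCCCn1ccnc1`: 23400 nM

Of these two, compound 2 has the higher number, 23400 nM, and so the weaker inhibition. Compound 3 `O=c1c2ccccc2c(-c2ccccc2)nn1CCCCCCn1ccnc1` is reached from it by one change: (1H-imidazol-1-yl)methyl in place of 1H-imidazol-1-yl on a saturated chain carbon, five bonds along the chain from an aromatic nitrogen. Among the measured compounds shown here, the only measured step that bears on this is a 2.1-fold higher number from compound 1 to compound 2 (0.33 log units; beyond the scatter), a modest one beyond the scatter. There, 2-(1H-imidazol-1-yl)ethyl takes the place of 1H-imidazol-1-yl, whereas here the entering group is only (1H-imidazol-1-yl)methyl. A single step cannot show whether the rise continues along the chain. A smaller step in the same direction is therefore expected in this assay, possibly no larger than the scatter. The expected step runs a 1.3-fold higher number from compound 2 to compound 3 (0.11 log units; within the scatter). The estimate for compound 3 is 30000 nM, with an expected range of 12000 nM to 70000 nM.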

Compound 3, half-maximal inhibitory concentration: 9770 nM
Beside the measured number, compound 3's estimate is 3.1-fold (0.49 log units) above it; measured number below the stated range.
By their numbers in this assay, from the lowest: compounds 3 and 1 (each within the scatter of the next); then compound 2.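

In this assay, the further extension of the chain, (1H-imidazol-1-yl)methyl in place of 1H-imidazol-1-yl five bonds along the chain from an aromatic nitrogen, does not carry on the earlier rise but reverses it, giving a 2.4-fold lower number from compound 2 to compound 3 (0.38 log units; beyond the scatter). Taken over the whole span, 3-(1H-imidazol-1-yl)propyl in place of 1H-imidazol-1-yl gives a 1.1-fold lower number from compound 1 to compound 3 (0.05 log units; within the scatter), so the two ends of this series cannot be told apart, and the number does not follow chain length in one direction, with compound 2 going against any such trend. Nothing available explains why the number falls again at this chain length.

Still open, as far as these compounds go, is how a longer chain, or one of a length falling between those of compound 1 and compound 2, would read out. From the compounds shown here alone, it is also open whether an amine or a carboxylic acid at the chain end could stand in for the 1H-imidazol-1-yl group.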